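The compounds below may be only part of what the source reports. "The series", "measured", "known", "first", "only" and "open" are said of these compounds alone.

In an ADME assay on cells (Macrophage, Mus musculus) for cytotoxicity, read by resazurin assay, with a stated time of 3 days (a lower number here means a stronger inhibitor, a higher number a weaker inhibitor), compound 1 `O=C(Nc1cc(C(F)(F)F)cc(C(F)(F)F)c1)c1cc(F)ccc1O` gives 2500 nM. Compound 2 `O=C(O)c1cccc(NC(=O)c2cc(Cl)ccc2O)c1` is a different case. For compound 2 this assay reports no number but only a limit, > 60000 nM. Compound 2 therefore stands at the limit of > 60000 nM in this assay, at which 1 of the 2 values shown sits, and its true value is not known beyond that.

Compound 3 `O=C(Nc1ccccc1)c1cccc(NC(=O)c2cc(Cl)ccc2O)c1` is built from compound 2 by one change: anilino in place of hydroxy on a carbonyl carbon whose other neighbour is an aromatic carbon. For the measured compounds named here, no measured pair shows this change, so its effect rests on expectation alone. The starting point is only a limit, so the step cannot be pinned tightly; the expectation is a move toward a lower number, the estimated step from compound 2 to compound 3 being an at least 3.0-fold lower number from compound 2 to compound 3 (0.47 log units; beyond the scatter). Compound 3 is accordingly expected to give about 20000 nM in this assay, within a range from 5000 nM to 60000 nM.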

Compound 3, half-maximal inhibitory concentration: > 60000 nM
Compound 3: only a limit was reported (the forecaster's own chance of this, stated with the estimate: 35%); at least 3.0-fold (0.47 log units) between middle value and limit.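

For the compounds shown here, compound 2 and compound 3 each give only a limit in this assay, not a number, and no step between them can be read. The compounds shown leave open how far past that limit their true values lie, and whether anilino in place of hydroxy shifts the value at all.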